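Coumarin propargylamines: trimming the benzyl arm

The compounds below may be only part of what the source reports. "The series", "measured", "known", "first", "only" and "open" are said of these compounds alone.

Measured so far:
compound 1, `C#CCN(CCCOc1ccc2ccc(=O)oc2c1)Cc1ccc(OC)cc1`, 6080 nM
compound 2, `C#CCN(CCCCOc1ccc2ccc(=O)oc2c1)Cc1ccc(C(C)C)cc1`, 3500 nM

In an assay on isolated protein for inhibition of Amine oxidase [flavin-containing] B (Homo sapiens), read by fluorescence and Amplex Red, with stated times of 15 min and 20 min (a higher number here means a weaker inhibitor, a lower number a stronger inhibitor), compound 1 gives 6080 nM, the higher of the two numbers; in this assay compound 2 gives 3500 nM, and the gap between the two lies within the scatter, so no order can be read from them. Among the measured compounds shown here, compound 1 and compound 2 differ in more than one place, and no single-point step between measured compounds is available to calibrate the change at hand.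

Compound 3, `C#CCN(C)CCCOc1ccc2ccc(=O)oc2c1`, differs from compound 1 by hydrogen in place of 4-methoxyphenyl on a saturated chain carbon bound to an amine nitrogen, that is, 4-methoxybenzyl gives way to methyl on the amine nitrogen. For the measured compounds named here, with no measured step to lean on, only a moderate shift is expected, in either direction, and most likely not far beyond the scatter, so a step of a 1.2-fold higher number from compound 1 to compound 3 (0.06 log units; within the scatter) is estimated. For compound 3 in this assay the expected value is 7000 nM, with a range from 2000 nM to 25000 nM.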

Compound 3, half-maximal inhibitory concentration: 1090 nM
Compound 3: middle estimate off by 6.4-fold (0.81 log units), on the high side, and the stated range ends above it.
By their numbers in this assay, from the lowest: compound 3; then compounds 2 and 1 (each within the scatter of the next).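

In this assay, among the compounds shown here, trimming 4-methoxybenzyl to methyl on the amine nitrogen gives a 5.6-fold lower number from compound 1 to compound 3 (0.75 log units; beyond the scatter), the first step that can be read beyond the scatter. The 4-methoxyphenyl, with its 8 heavy atoms and aromatic ring, is therefore not needed for inhibition in this compound, and the smaller methyl arm gives the lower number. No available measurement bears on the reason for this shift.

From the compounds shown here alone, whether an ethyl group or a bare hydrogen on the amine nitrogen would go lower than methyl remains open. Also open, going by these compounds, is whether the same trimming holds with the longer chain of compound 2, as compound 1 and compound 2 differ in more than one place and so do not separate the contribution of the chain from that of the benzyl arm.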